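Ester chain extension on the shared core: compound 3

This account rests on a few compounds, and the source may have more. Where it says the series, first, only, none or still open, it means among the compounds named here.

Two esters of the shared core have been measured. Compound 1 `CCCCCCOC(=O)CCC(=O)N1CCN(CCCOc2cc3c(Nc4ccc(F)c(Cl)c4)ncnc3cc2OC)CC1` in a functional assay on A549 cells (Homo sapiens) for cytotoxicity, read by MTT assay, with a stated time of 24 h, tested at 20 uM (a lower number here means a stronger effect, a higher number a weaker effect of the compound at the concentration tested), gives 85.1%, and compound 2 `CCCCCCCCCOC(=O)CCC(=O)N1CCN(CCCOc2cc3c(Nc4ccc(F)c(Cl)c4)ncnc3cc2OC)CC1` in this assay gives 79.7%. Compound 2 holds the smaller of the two numbers shown, though the step of a number 5.4 percentage points lower from compound 1 to compound 2 (within the scatter) lies within the scatter, so the two are not separated. Compound 3 `CCCCCCCCCCCCOC(=O)CCC(=O)N1CCN(CCCOc2cc3c(Nc4ccc(F)c(Cl)c4)ncnc3cc2OC)CC1` is not yet measured; it differs from compound 2 by propyl in place of hydrogen on a saturated chain carbon, nine bonds along the chain from an oxygen next to a carbonyl group. Going by the values given here, the only measured step that bears on this change is a number 5.4 percentage points lower from compound 1 to compound 2 (within the scatter), a change of the same kind placed six bonds along the chain from an oxygen next to a carbonyl group, and it stayed within the scatter. On that basis no step beyond the scatter is expected in this assay, with at most a slight drift in the same direction, and the expected step is a number 4.7 percentage points lower from compound 2 to compound 3 (within the scatter). Compound 3 is estimated at 75%, within a range of 62% to 88%.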

Compound 3, a percentage reported as activity, at one concentration (the size of the read-out at that concentration, not a potency): 86.8%
Compound 3: the middle estimate sits 11.8 percentage points below what was measured; the range from low to high includes it.
By their numbers in this assay, from the lowest: compounds 2, 1 and 3 (each within the scatter of the next).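

In this assay, moving the same propyl addition further out, to nine bonds along the chain from an oxygen next to a carbonyl group, gives a number 7.1 percentage points higher from compound 2 to compound 3 (within the scatter), so a change of this kind stays within the scatter at a second place on the chain. The full extension, hexyl in place of hydrogen six bonds along the chain from an oxygen next to a carbonyl group, gives a number 1.7 percentage points higher from compound 1 to compound 3 (within the scatter), so the three esters remain unseparated and show no trend with chain length. No evidence is available on what lies behind these read-outs.

Open, going by these compounds, is whether any change at this end of the molecule separates from these esters in this assay. A carboxylic acid or an amine at the chain end, or a methyl ester, would test this.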